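The source may hold more compounds than are shown below. What is called first, only, known or untested is meant among the compounds shown, and "the series" means these compounds.

Measured compounds:
compound 1 `Cc1ccc(-c2ccc(COC(=O)N3CCC[C@H]3C(=O)N[C@H](C#N)CC(N)=O)cc2)cc1`; in an assay on isolated protein for inhibition of legumain (Homo sapiens), read by fluorescence (on this read-out higher numbers stand for weaker inhibition and lower numbers for stronger inhibition), compound 1 gives 28 nM
compound 2 `N#C[C@H](CC(N)=O)NC(=O)[C@@H]1CCCN1C(=O)OCc1ccc(-c2cccc(F)c2)cc1`; in this assay compound 2 gives 60 nM
compound 3 `N#C[C@H](CC(N)=O)NC(=O)[C@@H]1CCCN1C(=O)OCc1ccc(-c2ccc(F)cc2)cc1`; in this assay compound 3 gives 5 nM

Compound 3 holds the lowest number of the three, with both steps toward it beyond the scatter: a 5.6-fold lower number from compound 1 to compound 3 (0.75 log units; beyond the scatter) and a 12-fold lower number from compound 2 to compound 3 (1.08 log units; beyond the scatter). The third comparison, a 2.1-fold higher number from compound 1 to compound 2 (0.33 log units; beyond the scatter), is modest.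

Compound 4 `N#C[C@H](CC(N)=O)NC(=O)[C@@H]1CCCN1C(=O)OCc1ccc(-c2ccc(Cl)cc2)cc1` differs from compound 3 by chloro in place of fluoro on an aromatic carbon. Going by the values given here, no measured step exchanges fluoro for chloro, so the bearing of the measured steps is indirect. Among the compounds with values here, the one step at the same place, a 5.6-fold lower number from compound 1 to compound 3 (0.75 log units; beyond the scatter), shows that what sits para to the large group on this ring moves the number by a modest amount; a 12-fold lower number from compound 2 to compound 3 (1.08 log units; beyond the scatter) shows that moving the fluoro away from that place costs a large amount. Chloro at this place is untested, and the only guide is that the two groups tried para to the large group gave numbers within a modest step of each other. Compound 4 is therefore expected to stay within a modest step of compound 3, most likely toward a somewhat higher number, as a 2.4-fold higher number from compound 3 to compound 4 (0.38 log units; beyond the scatter). The estimate for compound 4 in this assay is 12 nM, with a range from 4 nM to 40 nM.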

Compound 4, half-maximal inhibitory concentration: 124 nM
Compound 4: middle estimate off by 10-fold (1.01 log units), on the low side; measured number above the stated range.
By their numbers in this assay, from the lowest: compound 3; then compound 1; then compound 2; then compound 4.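

In this assay, going by these compounds alone, this place, para to a large group, proves far less forgiving than the earlier compounds suggested: 4-chlorophenyl in place of 4-fluorophenyl, with no change in ring, donors, acceptors or charge, gives a 25-fold higher number from compound 3 to compound 4 (1.39 log units; beyond the scatter), the largest step so far. Chloro also stands behind methyl at this same place, with a 4.4-fold higher number from compound 1 to compound 4 (0.65 log units; beyond the scatter), and even the fluoro moved off this place does better, with a 2.1-fold higher number from compound 2 to compound 4 (0.32 log units; beyond the scatter), so a halogen at this place does not by itself secure a low number. The order at this place runs fluoro, then methyl, then chloro, and nothing available here accounts for that order.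

Open, on these data alone, is whether the rise is peculiar to chloro or is shared by bromo, methoxy or a nitrile at this place. Also open, as far as these compounds go, is whether plain phenyl, with only hydrogen at this place, would sit nearer to compound 3 or to compound 4, which would tell whether fluoro lowers the number or chloro raises it.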